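Series notes on cytotoxicity, compounds 1 to 3

The source may report more compounds than this note shows. Statements on the series, on what has been measured and on what is new or still open speak of the compounds shown alone.

Compound 1 `Cc1ccc(-c2c(C#N)[n+]([O-])c3ccccc3[n+]2[O-])cc1` is the parent of the pair measured so far; in an ADME assay on Vero cells (Chlorocebus sabaeus) for cytotoxicity, read by MTT assay, with a stated time of 72 h (on this read-out lower numbers stand for stronger inhibition and higher numbers for weaker inhibition), compound 1 gives 0.68 ug/mL. Compound 2 `COc1ccc2c(c1)[n+]([O-])c(C#N)c(-c1ccc(C)cc1)[n+]2[O-]` carries a methoxy in place of hydrogen on the shared core, and in this assay compound 2 gives 3.8 ug/mL. Within the data shown here, the step of a 5.6-fold higher number from compound 1 to compound 2 (0.75 log units; beyond the scatter) is the only measured step in the set. Compound 2 therefore stands highest of the two numbers, with compound 1 the nearest neighbour.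

Compound 3 `COC(=O)c1ccc(-c2c(C#N)[n+]([O-])c3cc(OC)ccc3[n+]2[O-])cc1` is not yet measured. Relative to compound 2 the change is methoxycarbonyl in place of methyl on an aromatic carbon. Among the measured compounds shown here, no measured step touches this position: the single known step concerns the methoxy on the shared core and does not bear on an exchange at the six-membered aromatic ring of carbon only. Nothing in the data points to a direction for this assay, so the default expectation is a step not clearly beyond the scatter, a 1.1-fold higher number from compound 2 to compound 3 (0.02 log units; within the scatter). Compound 3 is accordingly estimated at 4 ug/mL, with a range from 1.5 ug/mL to 12 ug/mL.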

Compound 3, half-maximal inhibitory concentration: 3.9 ug/mL
For compound 3 the middle estimate is 1.0-fold (0.01 log units) above the measured one; the range from low to high includes it.
By their numbers in this assay, from the lowest: compound 1; then compounds 2 and 3 (each within the scatter of the next).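

In this assay, among these compounds, the exchange of methyl for methoxycarbonyl on the six-membered aromatic ring of carbon only, para to a large group, gives a 1.0-fold higher number from compound 2 to compound 3 (0.01 log units; within the scatter) and provides the first reading at this position, as the earlier step of a 5.6-fold higher number from compound 1 to compound 2 (0.75 log units; beyond the scatter) concerned the methoxy on the shared core. The entering methoxycarbonyl brings 4 heavy atoms and 2 hydrogen-bond acceptors in place of the 1 heavy atom of methyl, yet compound 3 remains within the scatter of compound 2, so this change does not produce the clear separation seen with the methoxy step. The data at hand offer no explanation for this result.

The exchange is seen here only on the methoxy-bearing core, so the same change on the core of compound 1 remains an open question, as does whether the two steps would simply add up there. The compounds shown also do not say whether a carboxylic acid or an amine at this position would stay within the scatter of compound 2 in this assay or move clearly away from it.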